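Urea series: oxazolyl to pyridazinyl swap at the chain carbon

The source may report more compounds than this note shows. Statements on the series, on what has been measured and on what is new or still open speak of the compounds shown alone.

Compound 1 `CCOC(=O)c1ccc(NC(=O)NCc2cocn2)cc1` is the reference point of this set. Among the measured compounds shown here, in an assay on isolated protein for activation of Nicotinamide phosphoribosyltransferase (Homo sapiens) (a lower number here means that less compound is needed, a higher number that more compound is needed for the effect), compound 1 gives 27600 nM, the only numerical value present among the two measured compounds. Compound 2 `CCOC(=O)c1ccc(N(C)C(=O)NCc2ccncc2)cc1` is the other measured member. In this assay compound 2 reaches only a limit, > 100000 nM, and no number. What the measured values show is thin: the limit of > 100000 nM in this assay, at which 1 of the 2 values shown sits. Compound 3 `CCOC(=O)c1ccc(NC(=O)NCc2ccnnc2)cc1` is not yet measured. It differs from compound 1 in one place: pyridazin-4-yl in place of 1,3-oxazol-4-yl on a saturated chain carbon bound to an amide-type nitrogen. For the measured compounds named here, no pair of measured compounds differing in only one place is present, so the size of this step has no measured anchor. The step of a 1.1-fold lower number from compound 1 to compound 3 (0.04 log units; within the scatter) is expected to be small, within the scatter or a little beyond it, and its direction is open. Compound 3 is estimated at 25000 nM, with a range from 6000 nM to 100000 nM.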

Compound 3, half-maximal effective concentration: > 100000 nM
Compound 3 gave a limit, no number; the forecaster's own chance of this, stated with the estimate: 25%; middle value at least 4.0-fold (0.60 log units) from the limit.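

Among the compounds shown here, this is the first measured step at this position: in this assay, pyridazin-4-yl in place of 1,3-oxazol-4-yl on a saturated chain carbon bound to an amide-type nitrogen gives an at least 3.6-fold higher number from compound 1 to compound 3 (0.55 log units; beyond the scatter). The step is a lower bound, since the value for compound 3 is a limit and not a number. The two groups have equal hydrogen-bond donor and acceptor counts, so matching those counts does not keep a measurable value here, and compound 1 remains the only compound with a number: the limit of > 100000 nM in this assay, at which 2 of the 3 values shown sit.

As far as these compounds go, the true size of the step remains open, as does whether the six-membered ring or the placement of its hetero atoms matters. A 1,3-thiazol-4-yl group or a phenyl ring on the same chain carbon would help separate the two.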